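The compounds below may be only part of what the source reports. "The series", "measured", "known", "first", "only" and "open" are said of these compounds alone.

For the measured compounds named here, compound 3 `Cc1csc(/N=C/c2ccccc2C)n1` gives 331 nM in an assay on mitochondria for inhibition of Amine oxidase [flavin-containing] B (Bos taurus) (on this read-out lower numbers stand for stronger inhibition and higher numbers for weaker inhibition), the highest of the three numbers so far, though compound 2 `Clc1ccc(/C=N/Nc2nc(-c3ccccc3)cs2)cc1`, with 170 nM, lies within the scatter of it, and only compound 1 `C(=N/Nc1nc(-c2ccccc2)cs1)\c1ccccc1`, with 91.2 nM, stands beyond it. Compound 4 `Cc1ccccc1/C=N/c1nc(-c2ccccc2)cs1` differs from compound 3 by phenyl in place of methyl on an aromatic carbon. Going by the values given here, no measured step covers this change on its own: compounds 1 and 2 carry a phenyl at that place but also differ from compound 3 in the link between the two rings, and the single measured step, a 1.9-fold higher number from compound 1 to compound 2 (0.27 log units; within the scatter), concerns a chloro group, not this one. The account therefore expects only a modest shift for compound 4 in this assay, of a 1.8-fold lower number from compound 3 to compound 4 (0.26 log units; within the scatter), leaning toward a lower number. Compound 4 is estimated at 180 nM, within 50 nM to 650 nM.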

Compound 4, inhibition constant: 501 nM
The estimate for compound 4 lay 2.8-fold (0.44 log units) below the measured number, within the range that was stated.
By their numbers in this assay, from the lowest: compounds 1, 2, 3 and 4 (each within the scatter of the next, the first and the last beyond it).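

In this assay, for the compounds shown here, the first direct reading at this position, replacing methyl with phenyl on the aromatic carbon next to the ring nitrogen gives a 1.5-fold higher number from compound 3 to compound 4 (0.18 log units; within the scatter). Compounds 1 and 2 carry phenyl there but differ in the link, so they could not isolate this change; here the added aromatic ring produces no step beyond the scatter. Nothing available explains this result.

From the compounds shown here alone, it remains open whether an amine or a carboxylic acid on this carbon would also stay within the scatter. Going by these compounds, it is equally open whether this exchange would give a similar step with the link in compounds 1 and 2.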